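Notes on the shared core: configuration at the ring stereocentre

The source may report more compounds than this note shows. Statements on the series, on what has been measured and on what is new or still open speak of the compounds shown alone.

compound 1, `Cc1c(CO)cc2n1[C@@H](c1ccccc1)SC2`: 4300 nM in a functional assay on MCF7 cells (Homo sapiens) for cytotoxicity, read by MTT assay, with a stated time of 48 h; a higher number here means a weaker inhibitor, a lower number a stronger inhibitor
compound 2, `Cc1c(CO)c(CO)c2n1[C@@H](c1ccccc1)SC2`: 1900 nM in this assay
compound 3, `OCc1cn2c(c1CO)CS[C@@H]2c1ccccc1`: 19400 nM in this assay

Compound 2 gives the lowest number of the three in this assay; compound 1 is nearest, separated by a 2.3-fold lower number from compound 1 to compound 2 (0.35 log units; beyond the scatter), and compound 3 furthest, separated by a 10-fold higher number from compound 2 to compound 3 (1.01 log units; beyond the scatter). Compound 4, `Cc1c(CO)c(CO)c2n1[C@H](c1ccccc1)SC2`, keeps every atom and bond of compound 2: the two compounds have the same atoms and bonds and differ only in configuration as drawn: 1 of 1 stereo elements differ; a stereocentre at a saturated ring carbon is drawn R in compound 2 and S in compound 4. Neither measured step involves a change of configuration; both concern a substituent on an aromatic carbon, so neither bears on this step, and the series gives no basis for its size or direction. Inversion at the single stereocentre could move the number either way in this assay. Leaning slightly toward a higher number and with a wide span, the estimate for compound 4 is 3500 nM (range 1000 nM to 15000 nM), which is expected to mean a 1.8-fold higher number from compound 2 to compound 4 (0.27 log units; within the scatter).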

Compound 4, half-maximal inhibitory concentration: 540 nM
Beside the measured number, compound 4's estimate is 6.5-fold (0.81 log units) above it; measured number outside the range, below it.
By their numbers in this assay, from the lowest: compound 4; then compound 2; then compound 1; then compound 3.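

In this assay the saturated ring carbon proves to be a position that matters, since R to S gives a 3.5-fold lower number from compound 2 to compound 4 (0.55 log units; beyond the scatter) and leaves compound 4 with the lowest number of the series. The earlier steps shown here showed only that substituents on aromatic carbons move the number, whereas here configuration alone does so. The shift can be assigned to this stereocentre alone: the fact that compounds 2 and 4 differ only in the configuration as drawn

Open, as far as these compounds go, is whether inversion gives a step of like size starting from compound 1 or compound 3. Also open, from the compounds shown here alone, is how an amine or a carboxylic acid in place of hydroxymethyl would change the number with the S configuration.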